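The source may report more compounds than this note shows. Statements on the series, on what has been measured and on what is new or still open speak of the compounds shown alone.

For the measured compounds named here, in an assay on HEK293 cells for inhibition of Voltage-dependent T-type calcium channel subunit alpha-1G (Homo sapiens), read by patch clamp (a lower number here means a stronger inhibitor, a higher number a weaker inhibitor), compound 2 `CCCc1nc(-c2ccccc2)c(CNCCN2CCN(c3ccccc3C)CC2)o1` gives 4300 nM, standing highest of the two numbers so far, though only within the scatter of compound 1 `CCCc1nc(-c2ccccc2)c(CNCCN2CCN(c3ccc(Cl)cc3)CC2)o1`, which gives 2820 nM. Going by the values given here, the single measured step, a 1.5-fold higher number from compound 1 to compound 2 (0.18 log units; within the scatter), lay within the scatter. Compound 3 `CCCc1nc(-c2ccccc2)c(CNCCN2CCN(c3ccc(OC)cc3)CC2)o1` varies the same position: 4-methoxyphenyl in place of 2-methylphenyl on an amine nitrogen in a ring. Among the compounds with values here, the one step that bears on it, the earlier exchange of the aryl group on the ring nitrogen, did not move the number beyond the scatter, so no step beyond the scatter, in either direction, is expected here. Compound 3 is therefore estimated at 3500 nM, with a range from 1500 nM to 8000 nM, an expected step of a 1.2-fold lower number from compound 2 to compound 3 (0.09 log units; within the scatter).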

Compound 3, half-maximal inhibitory concentration: 9200 nM
Estimate against measurement, compound 3: 2.6-fold (0.42 log units) below, outside the stated range (above it).
By their numbers in this assay, from the lowest: compounds 1 and 2 (each within the scatter of the next); then compound 3.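

In this assay this position now shows a change beyond the scatter: 4-methoxyphenyl in place of 2-methylphenyl gives a 2.1-fold higher number from compound 2 to compound 3 (0.33 log units; beyond the scatter), though the step is modest. Methoxy in place of chloro on the aromatic carbon gives a 3.3-fold higher number from compound 1 to compound 3 (0.51 log units; beyond the scatter), so the substituent on this aryl group can shift the number, which the earlier exchange did not show. Nothing available accounts for this shift.

Still open, on these data alone, is how an amine or a carboxylic acid on that aromatic carbon, or a plain phenyl on the ring nitrogen, would read. Also open, as far as these compounds go, is whether any group here gives a number clearly lower than that of compound 1.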